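The source may hold more compounds than are shown below. What is called first, only, known or untested is meant among the compounds shown, and "the series" means these compounds.

Of the compounds shown here, two carrying the same thiazolidinedione-bearing core have been measured in a functional assay on the whole organism (plasma, strain Wistar) with Rattus norvegicus as the target, with a stated time of 15 days, at a dose of 3 mg/kg by the oral route; on this read-out higher numbers stand for a stronger effect at the one dose given and lower numbers for a weaker effect. Compound 1 `Cc1nc(COc2ccc(/C=C3\SC(=O)NC3=O)cc2)cs1` gives 10.4% in this assay. Compound 2 `O=C1NC(=O)/C(=C/c2ccc(OCCSc3nnc(Cc4ccccc4)o3)cc2)S1` gives 14.2% in this assay, the higher of the two numbers, although the gap to compound 1 lies within the usual scatter, so the two cannot be ordered against each other. Compound 3 `O=C1NC(=O)/C(=C/c2ccc(OCCSc3nnc(-c4ccncc4)o3)cc2)S1` has not yet been measured. Its structure departs from compound 2 in one respect: pyridin-4-yl in place of benzyl on an aromatic carbon. Going by the values given here, no measured pair in this set shows what such an exchange does, so the direction of the step is open. Given that compound 1 and compound 2 both sit in a narrow low band, the step is expected to stay within the scatter, at a number 1.2 percentage points lower from compound 2 to compound 3 (within the scatter). Compound 3 is accordingly estimated to give 13% in this assay, with a plausible range from 3% to 26%.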

Compound 3, a percentage reported as activity, at one dose (the size of the read-out at that dose, not a potency): 23.5%
Compound 3: middle estimate off by 10.5 percentage points, on the low side; the range from low to high includes it.
By their numbers in this assay, from the lowest: compounds 1, 2 and 3 (each within the scatter of the next, the first and the last beyond it).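

In this assay, putting pyridin-4-yl in place of benzyl on this aromatic carbon of the five-membered ring gives a number 9.3 percentage points higher from compound 2 to compound 3 (within the scatter), the first step read at this position. The step stays within the scatter, so the position takes a six-membered aromatic ring with one nitrogen and one heavy atom fewer in the group without a change that can be told from repeat variation. Nothing measured here bears on why the step has this size.

This single exchange alters the ring and the group's heavy-atom count together, so the compounds shown cannot separate the two. On these data alone, what a plain phenyl group, an amine or a carboxylic acid on this carbon would give remains open.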